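Compound 3 to compound 4: one more ethyl on the chain

This account rests on a few compounds, and the source may have more. Where it says the series, first, only, none or still open, it means among the compounds named here.

Three esters sharing one core have been read in an ADME assay on Vero cells (Chlorocebus sabaeus) for cytotoxicity, read by reporter gene assay, with a stated time of 4 days (a lower number here means a stronger inhibitor, a higher number a weaker inhibitor), so far. Compound 1 (`CCCC(C)C(=O)OCC(C)(C)CC1=C(O)C(=O)c2ccccc2C1=O`) gives 120 nM and stands alone at the low end of the numbers. Compound 2 (`CCCCCCC(=O)OCC(C)(C)CC1=C(O)C(=O)c2ccccc2C1=O`) gives 99300 nM and compound 3 (`CCCCCCCCC(=O)OCC(C)(C)CC1=C(O)C(=O)c2ccccc2C1=O`) gives 150000 nM in the same measurement. Compound 3 therefore sits level with compound 2 and far from compound 1.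

Compound 4 (`CCCCCCCCCCC(=O)OCC(C)(C)CC1=C(O)C(=O)c2ccccc2C1=O`) is the next member to read. Its difference from compound 3 is ethyl in place of hydrogen on a saturated chain carbon, eight bonds along the chain from a carbonyl carbon and the rest of the structure stays the same.

Within the data shown here, the closest precedent is the same kind of change, ethyl in place of hydrogen on a saturated chain carbon, six bonds along the chain from a carbonyl carbon. It gave a 1.5-fold higher number from compound 2 to compound 3 (0.18 log units; within the scatter) and so stayed within the scatter. The two large steps, an 830-fold higher number from compound 1 to compound 2 (2.92 log units; beyond the scatter) and a 1300-fold higher number from compound 1 to compound 3 (3.10 log units; beyond the scatter), are of another kind, with hexyl or octyl in place of 1-methylbutyl on a carbonyl carbon, so they bear little on this change. Among the measured compounds shown here, only one precedent exists, so the expectation is tentative: no step beyond the scatter, in either direction.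

The estimated step is a 1.1-fold higher number from compound 3 to compound 4 (0.05 log units; within the scatter) in this assay. Compound 4 is expected at 170000 nM, with an estimated range from 80000 nM to 350000 nM.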

Compound 4, half-maximal inhibitory concentration: > 233000 nM
Compound 4 ended at the assay's limit; the forecaster's own chance of this, stated with the estimate: 20%; middle value at least 1.3-fold (0.13 log units) away from the limit.
By their numbers in this assay, from the lowest: compound 1; then compounds 2 and 3 (each within the scatter of the next). At a limit, above all of these: compound 4.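

Compound 4 stands at a limit and not at a number in this assay, so only a floor can be read for this change at this position: the limit of > 233000 nM in this assay, at which 1 of the 4 values shown sits.

Ethyl in place of hydrogen, eight bonds along the chain from a carbonyl carbon, gives an at least 1.5-fold higher number from compound 3 to compound 4 (0.19 log units; that floor lies within the scatter), so this step alone cannot be told apart from no change, although its true size may be larger. Butyl in place of hydrogen, six bonds along the chain from a carbonyl carbon, gives an at least 2.3-fold higher number from compound 2 to compound 4 (0.37 log units; beyond the scatter), the first step beyond the scatter among compounds 2, 3 and 4, while the widest comparison gives an at least 1900-fold higher number from compound 1 to compound 4 (3.28 log units; beyond the scatter), which leaves compound 4 as far from compound 1 as the large steps already printed, or further.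

As far as these compounds go, the true value of compound 4 remains open, as does how far the number would rise with this change. Also open, from the compounds shown here alone, is whether 1-methylbutyl differs from hexyl through its branch or its chain length, and what a shorter chain such as butyl, or an amine or a carboxylic acid on the chain, would give.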